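The source may report more compounds than this note shows. Statements on the series, on what has been measured and on what is new or still open speak of the compounds shown alone.

Two compounds share one core. Compound 1 `COc1cc(Cl)cc(-c2nn(-c3cccc(NC(=O)Nc4ccc(Cl)c(C(F)(F)F)c4)c3)cc2-c2ccncc2)c1` and compound 2 `COc1cc(Cl)cc(-c2nn(-c3cccc(NC(=O)c4cccc(C(F)(F)F)c4)c3)cc2-c2ccncc2)c1` were tested in a functional assay on SK-MEL-5 cells (Homo sapiens) for inhibition, read by sulforhodamine B assay, with a stated time of 48 h, tested at 1 uM; on this read-out lower numbers stand for a stronger effect and higher numbers for a weaker effect at the one concentration tested. In this assay compound 1 gives 83%, and compound 2 gives 57%. For the measured compounds named here, the single measured step, a number 26 percentage points lower from compound 1 to compound 2 (beyond the scatter), concerns 3-(trifluoromethyl)phenyl in place of (4-chloro-3-(trifluoromethyl)phenyl)amino on a carbonyl carbon. On the two numbers shown, compound 1 stands highest, which on this read-out means the weaker effect of the pair.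

Compound 3 `O=C(Nc1cccc(-n2cc(-c3ccncc3)c(-c3cc(O)cc(Cl)c3)n2)c1)Nc1ccc(Cl)c(C(F)(F)F)c1` has not been measured. It differs from compound 1 by hydrogen in place of methyl on an oxygen on an aromatic ring. Going by the values given here, no measured step touches this part of the molecule; the one step on record sits at the carbonyl end and tells nothing about the oxygen on the aromatic ring. The account therefore rests on compound 1 alone, at 83%, and on the absence of any comparable change.

With nothing to point either way, the expected step of a number 3 percentage points lower from compound 1 to compound 3 (within the scatter) is none beyond the scatter. Compound 3 is estimated at 80%, with a range from 55% to 100%.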

Compound 3, a percentage reported as activity, at one concentration (the size of the read-out at that concentration, not a potency): 90%
Compound 3: the middle estimate sits 10 percentage points below what was measured, within the range that was stated.
By their numbers in this assay, from the lowest: compound 2; then compounds 1 and 3 (each within the scatter of the next).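

For the compounds shown here, the first reading at this position comes from the change from 3-chloro-5-methoxyphenyl to 3-chloro-5-hydroxyphenyl, where this assay gives a number 7 percentage points higher from compound 1 to compound 3 (within the scatter) and so does not separate the two compounds. Hydrogen in place of methyl on this oxygen therefore leaves the read-out within the scatter at the one concentration tested, unlike the change at the carbonyl end, which gave a number 26 percentage points lower from compound 1 to compound 2 (beyond the scatter) and remains the only step shown that lies beyond the scatter. No measurement shown here offers an explanation for this result.

Going by these compounds, what remains open is whether an ethoxy group, a longer chain on this oxygen, or an amine in place of the hydroxy group would also read within the scatter of compound 1, and whether the same methoxy to hydroxy change would do so when 3-(trifluoromethyl)phenyl sits on the carbonyl carbon, as in compound 2. A single concentration also leaves open whether compound 1 and compound 3 would stay together at other concentrations, which a full concentration series could show.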